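This account rests on a few compounds, and the source may have more. Where it says the series, first, only, none or still open, it means among the compounds named here.

Compound 3 `CC1=NC(C)=C(C(=O)O)C(c2cccc(Cl)c2)/C1=C(\O)OC/C=C/c1ccccc1` stands second of the three measured compounds in a functional assay on thoracic aorta for inhibition of Voltage-gated L-type calcium channel (Rattus norvegicus) (a lower number here means a stronger inhibitor, a higher number a weaker inhibitor), giving 20 nM. Nearest to it is compound 2 `CC1=NC(C)=C(C(=O)O)C(c2ccccc2)/C1=C(\O)OC/C=C/c1ccccc1`, which gives 9 nM, the step being a 2.2-fold higher number from compound 2 to compound 3 (0.35 log units; beyond the scatter). Furthest is compound 1 `CC1=NC(C)=C(C(=O)O)C(c2ccc([N+](=O)[O-])cc2)/C1=C(\O)OC/C=C/c1ccccc1`, which gives 1600 nM; the steps of a 180-fold lower number from compound 1 to compound 2 (2.25 log units; beyond the scatter) and an 80-fold lower number from compound 1 to compound 3 (1.90 log units; beyond the scatter) are both large.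

Compound 4 `CC1=NC(C)=C(C(=O)O)C(c2cccc(Br)c2)/C1=C(\O)OC/C=C/c1ccccc1` differs from compound 3 by bromo in place of chloro on an aromatic carbon, the swap sitting on an aromatic carbon of a six-membered aromatic ring of carbon only. Among the measured compounds shown here, none of the measured steps involves a swap of one halogen for another: the large steps concern removal of the nitro group, and the modest step concerns chloro in place of hydrogen. The change from compound 3 to compound 4 is therefore without a direct precedent among these compounds, and since it exchanges one single heavy atom for another of the same kind of group, no step beyond the scatter is expected in this assay. The estimate for compound 4 in this assay is 20 nM, with a range from 8 nM to 50 nM, corresponding to an expected step of no change at the digits printed from compound 3 to compound 4 (within the scatter).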

Compound 4, half-maximal inhibitory concentration: 10 nM
Estimate against measurement, compound 4: 2.0-fold (0.30 log units) above; measured number inside the range.
By their numbers in this assay, from the lowest: compounds 2, 4 and 3 (each within the scatter of the next, the first and the last beyond it); then compound 1.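

In this assay, among the compounds shown here, the swap of chloro for bromo on this aromatic carbon, meta to a large group, gives a 2.0-fold lower number from compound 3 to compound 4 (0.30 log units; within the scatter) and so does not separate the two halogens, which the earlier compounds could not show, as none of their steps exchanged one halogen for another. Bromo also stands level with the unsubstituted phenyl, with a 1.1-fold higher number from compound 2 to compound 4 (0.05 log units; within the scatter) inside the scatter, although the chloro step from that same compound lay just beyond it, while the 3-bromophenyl compound keeps the wide distance from the 4-nitrophenyl compound, seen in a 160-fold lower number from compound 1 to compound 4 (2.20 log units; beyond the scatter) as a large step. No measurement shown here accounts for any of these numbers.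

The compounds shown leave open whether a group other than a halogen on this same aromatic carbon, such as methoxy, an amine or a carboxylic acid, would stay as close to the unsubstituted compound as bromo does. They also leave open how much of the large step belongs to the nitro group itself and how much to the place it occupies, as compound 1 differs from the others in both.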